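The compounds below may be only part of what the source reports. "The series", "measured", "known", "first", "only" and "open" are said of these compounds alone.

Compound 1 `COc1cc(-c2nn(-c3cccc(NC(=O)c4cccc(C(F)(F)F)c4)c3)cc2-c2ccncc2)ccc1Cl` carries an amide whose acyl part is 3-(trifluoromethyl)phenyl. In a functional assay on 786-0 cells (Homo sapiens) for inhibition, read by sulforhodamine B assay, with a stated time of 48 h (a lower number here means a stronger inhibitor of growth, a higher number a weaker inhibitor of growth), compound 1 gives > 50000 nM, which is a limit of the assay rather than a number, as the limit of > 50000 nM in this assay, at which 1 of the 3 values shown sits, records. Two companions share most of the core but carry a urea in place of the amide and a hydroxyl where compound 1 has a methoxy group. Compound 2 `O=C(Nc1cccc(-n2cc(-c3ccncc3)c(-c3ccc(Cl)c(O)c3)n2)c1)Nc1cc(C(F)(F)F)cc(C(F)(F)F)c1` gives 3160 nM in this assay. Compound 3 `O=C(Nc1cccc(-n2cc(-c3ccncc3)c(-c3ccc(Cl)c(O)c3)n2)c1)Nc1ccc(Cl)c(C(F)(F)F)c1` gives > 32500 nM in this assay, again a limit and not a number, as the limit of > 32500 nM in this assay, at which 1 of the 3 values shown sits, shows. Among the three, compound 2 is the only one with a measured number, while compound 1 sits at a limit.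

Compound 4 `COc1cc(-c2nn(-c3cccc(NC(=O)Nc4ccc(Cl)c(Cl)c4)c3)cc2-c2ccncc2)ccc1Cl` has not yet been measured. It differs from compound 1 in one place: (3,4-dichlorophenyl)amino in place of 3-(trifluoromethyl)phenyl on a carbonyl carbon. The carbonyl thus carries a (3,4-dichlorophenyl)amino group, so the amide becomes a urea. Compound 2 shows that a urea of this kind can reach a measurable number, yet compound 3 shows that another urea does not, so any expectation stays loose. Compound 4 is expected to come in at 30000 nM, within 5000 nM to 80000 nM, an expected step of an at least 1.6-fold lower number from compound 1 to compound 4 (0.22 log units; that floor lies within the scatter) toward somewhat stronger inhibition, with a real chance that only a limit is reported again.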

Compound 4, concentration for total growth inhibition: 4470 nM
Compound 4: the middle estimate sits 6.7-fold (0.83 log units) above what was measured, outside the stated range (below it).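

In this assay, putting (3,4-dichlorophenyl)amino in place of 3-(trifluoromethyl)phenyl on the carbonyl carbon turns the amide into a urea and gives an at least 11-fold lower number from compound 1 to compound 4 (1.04 log units; beyond the scatter), a large gain in growth inhibition from a change at this one place. Going by these compounds alone, compound 2 and compound 3 differ from compound 1 in more than one place, so only this pair isolates the carbonyl substituent, and it shows that a urea can reach a measured number with the methoxy group of compound 1 kept and no hydroxyl present. The printed step is only a minimum, because compound 1 is recorded as a limit and not as a number: the limit of > 50000 nM in this assay, at which 1 of the 4 values shown sits.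

This single step changes both the link, by adding the urea nitrogen, and the ring substituents, by replacing trifluoromethyl with two chlorines, and the compounds shown do not separate the two changes. Also open, on these data alone, is what a cyclohexyl group or a morpholine on the same carbonyl carbon would do in place of the (3,4-dichlorophenyl)amino group.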